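Chloro to hydrogen on compound 2: expected shift

A few compounds are considered here, and "the series" means these few. Any claim that something is new, unique, unknown or untested is made for them only; others in the source may bear on it.

Among the compounds with values here, compound 2 `Cc1cc(OCc2c(-c3c(Cl)cn(C)c(=O)c3Cl)noc2C(C)C)ccc1-c1ccc2c(C(=O)O)cn(C)c2c1` gives 2750 nM in an assay on isolated protein for displacement of a labelled ligand from Bile acid receptor (Homo sapiens), read by scintillation proximity assay and radioligand binding (a higher number here means a weaker inhibitor, a lower number a stronger inhibitor), the highest of the two numbers measured so far; compound 1 `Cc1cc(OCc2c(-c3cc[nH]c(=O)c3Cl)noc2C(C)C)ccc1-c1ccc2c(C(=O)O)cn(C)c2c1` gives 1100 nM. Compound 3 `Cc1cc(OCc2c(-c3ccn(C)c(=O)c3Cl)noc2C(C)C)ccc1-c1ccc2c(C(=O)O)cn(C)c2c1` differs from compound 2 by hydrogen in place of chloro on an aromatic carbon. Within the data shown here, the only measured step, a 2.5-fold higher number from compound 1 to compound 2 (0.40 log units; beyond the scatter), changed more than the chloro alone, so the share of that chloro is not separable from the rest of it. Since compound 3 undoes only part of that change, a partial return toward the number of compound 1 is expected, a 1.5-fold lower number from compound 2 to compound 3 (0.18 log units; within the scatter). Compound 3 is expected to give 1800 nM, with a range of 900 nM to 3600 nM.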

Compound 3, half-maximal inhibitory concentration: 1720 nM
Compound 3: the middle estimate sits 1.0-fold (0.02 log units) above what was measured, and the stated range covers the measured number.
By their numbers in this assay, from the lowest: compounds 1, 3 and 2 (each within the scatter of the next, the first and the last beyond it).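

In this assay both a 1.6-fold lower number from compound 2 to compound 3 (0.20 log units; within the scatter) and a 1.6-fold higher number from compound 1 to compound 3 (0.19 log units; within the scatter) stay within the scatter, so neither removing this chloro from the aromatic carbon nor adding methyl on the aromatic nitrogen is resolved as a change on its own. Only compound 1 and compound 2, which differ in both places, lie beyond the scatter of each other. No measurement here bears on a cause for this.

Open, on these data alone, is whether an amine or a methoxy group on this aromatic carbon, or an ethyl group on the ring nitrogen, would move the number beyond the scatter.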